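One Halogen Exchange Tested on Two Related Cores

The source may hold more compounds than are shown below. What is called first, only, known or untested is meant among the compounds shown, and "the series" means these compounds.

Of the compounds shown here, three have been measured so far in a functional assay on NCI-H1975 cells (Homo sapiens) for inhibition, read by MTT assay, with a stated time of 72 h; on this read-out higher numbers stand for weaker inhibition and lower numbers for stronger inhibition. Compound 1, `O=C(CSc1nc(Nc2ccccc2)c2ccccc2n1)Nc1ccccc1Cl`, gives 9610 nM in this assay. Compound 2, `O=C(CSc1nc(Nc2ccccc2)c2ccccc2n1)Nc1ccccc1Br`, gives 10300 nM in this assay. Compound 3, `C=CC(=O)Nc1cccc(NC(=O)CSc2nc(Nc3ccccc3Cl)c3ccccc3n2)c1`, gives 10000 nM in this assay. All three numbers sit within the usual scatter of one another, so none of them can be set apart from the others.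

From compound 1 to compound 2 the structural change is bromo in place of chloro on an aromatic carbon, and the step it made in this assay is a 1.1-fold higher number from compound 1 to compound 2 (0.03 log units; within the scatter). How the core of compound 3 differs from the core of compound 1 is not broken down here.

Compound 4, `C=CC(=O)Nc1cccc(NC(=O)CSc2nc(Nc3ccccc3Br)c3ccccc3n2)c1`, has not yet been measured. From compound 3 to compound 4 the change is bromo in place of chloro on an aromatic carbon, which is the same change, at a place described in the same words, as the one from compound 1 to compound 2; among the compounds shown it occurs twice in all.

In this assay the step from compound 3 to compound 4 is expected to be a 1.1-fold higher number from compound 3 to compound 4 (0.02 log units; within the scatter). Among the measured compounds shown here, this expectation rests on the single measured precedent, because a 1.1-fold higher number from compound 1 to compound 2 (0.03 log units; within the scatter) is the only instance of this change for which both numbers are known. Compound 4 is therefore estimated to give about 10500 nM in this assay. Its value is expected to fall between 5000 nM and 22000 nM in this assay.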

Compound 4, half-maximal inhibitory concentration: 19300 nM
For compound 4 the middle estimate is 1.8-fold (0.26 log units) below the measured one; measured number inside the range.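

In this assay the second instance of bromo in place of chloro on an aromatic carbon is a 1.9-fold higher number from compound 3 to compound 4 (0.29 log units; within the scatter), and the two instances compare as follows: the same change on two cores in this assay, a 1.1-fold higher number (0.03 log units; within the scatter) from compound 1 to compound 2 and a 1.9-fold higher number (0.29 log units; within the scatter) from compound 3 to compound 4, 1.8-fold (0.26 log units) apart, within the scatter of two such steps. As far as this assay can tell, then, the exchange carries from one core to the other without a difference that stands out from the ordinary spread of the measurements, and the result gives no ground for treating the two cores as responding differently. It does not show that the two steps are truly equal or that the exchange has any real effect on either core, for each step on its own lies within the scatter, and two pairs that both show no clear step are a weak test of transfer, with nothing here to say whether a large step would carry over in the same way.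

The compounds shown leave open whether other groups in the same place, such as fluoro, methyl or methoxy, would also behave alike on both cores. They also leave open whether the exchange would hold on a further core carrying an amine or a carboxylic acid.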